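This account rests on a few compounds, and the source may have more. Where it says the series, first, only, none or still open, it means among the compounds named here.

compound 1 `CC1=NN(C(=O)CSc2ccccn2)[C@@H](c2cc(Br)cc(Br)c2O)C1` gives 12300 nM
compound 2 `CC1=NN(C(=O)CSc2ccccc2)[C@@H](c2cc(Br)cc(Br)c2O)C1` gives 12700 nM
compound 3 `CC1=NN(C(=O)CSc2ccc(Br)cc2)[C@@H](c2cc(Br)cc(Br)c2O)C1` gives 12800 nM

All three numbers come from a functional assay on MGC-803 cells (Homo sapiens) for cytotoxicity, read by MTT assay, with a stated time of 48 h (on this read-out lower numbers stand for stronger inhibition and higher numbers for weaker inhibition), and the compounds differ only in the group on the sulfur of the side chain. Compound 3 stands level with the other two. The steps that reach it (a 1.0-fold higher number from compound 1 to compound 3 (0.02 log units; within the scatter)) and (a 1.0-fold higher number from compound 2 to compound 3 (0.00 log units; within the scatter)) lie within the scatter, as does the remaining step (a 1.0-fold higher number from compound 1 to compound 2 (0.01 log units; within the scatter)). Among these three compounds, then, changing the group on this sulfur has shown no measurable effect.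

Compound 4 `CC1=NN(C(=O)CSc2nc3ccccc3s2)[C@@H](c2cc(Br)cc(Br)c2O)C1` keeps the shared core and has 1,3-benzothiazol-2-yl in place of 4-bromophenyl on the same sulfur (1,3-benzothiazol-2-yl in place of 4-bromophenyl on a sulfur). Within the data shown here, no measured compound carries this group, and three compounds are a thin basis for judging a new one. The best available guide is still the flat run of steps at this position, especially (a 1.0-fold higher number from compound 1 to compound 3 (0.02 log units; within the scatter)), where one aromatic group replaced another on the sulfur. The expected change in this assay is therefore none beyond the scatter (a 1.2-fold lower number from compound 3 to compound 4 (0.07 log units; within the scatter)). Compound 4 is estimated at 11000 nM (expected range 5500 nM to 20000 nM).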

Compound 4, half-maximal inhibitory concentration: 7800 nM
Estimate against measurement, compound 4: 1.4-fold (0.15 log units) above; the measured number falls inside the stated range.
By their numbers in this assay, from the lowest: compounds 4, 1, 2 and 3 (each within the scatter of the next).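

In this assay, this position on the sulfur accepts a larger group without a change that can be read: 1,3-benzothiazol-2-yl, which adds a five-membered aromatic ring with 2 hetero atoms to a six-membered aromatic ring, stays within the scatter of all three earlier groups (a 1.6-fold lower number from compound 3 to compound 4 (0.22 log units; within the scatter); a 1.6-fold lower number from compound 2 to compound 4 (0.21 log units; within the scatter); a 1.6-fold lower number from compound 1 to compound 4 (0.20 log units; within the scatter)). All three steps point the same way, but none lies beyond the scatter, so compound 4 cannot be called stronger than the others, and the flat picture at this position now extends from single aromatic rings to this two-ring group, which also brings the hydrogen-bond acceptors counted for it. Nothing available here accounts for how these four groups compare.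

As far as these compounds go, every group on this sulfur so far is aromatic, so it remains open whether the number would stay this flat with a saturated ring such as cyclohexyl, a butyl chain, or a chain ending in an amine or a carboxylic acid. The sulfur itself also stays the same throughout, which leaves open what an oxygen in its place would do.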